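A Dimethoxyphenyl Swap in a Growth Inhibitor Series

The source may hold more compounds than are shown below. What is called first, only, known or untested is meant among the compounds shown, and "the series" means these compounds.

In a functional assay on A549 cells (Homo sapiens) for inhibition, read by sulforhodamine B assay (a higher number here means a weaker inhibitor of growth, a lower number a stronger inhibitor of growth), compound 1 (`c1ccc(-c2ccc(-c3ccc(-c4nc5ccccc5[nH]4)cc3)cc2)cc1`) gives 41200 nM. Compound 2 (`Cc1ccc2[nH]c(-c3ccc(-c4ccc(-c5ccc(N(C)C)cc5)cc4)cc3)nc2c1`) gives 3510 nM, well under compound 1 and level with compound 3 (`Cc1ccc2[nH]c(-c3ccc(-c4ccc(-c5cccc(Cl)c5)cc4)cc3)nc2c1`) at 2800 nM. Compound 4 (`COc1ccc(-c2ccc(-c3ccc(-c4nc5cc(C)ccc5[nH]4)cc3)cc2)cc1OC`) is compound 2 with 3,4-dimethoxyphenyl in place of 4-(dimethylamino)phenyl on an aromatic carbon. Among the compounds with values here, one measured step bears on this change, a replacement of the same group by 3-chlorophenyl, and it is a 1.3-fold lower number from compound 2 to compound 3 (0.10 log units; within the scatter). On that single step, no change beyond the scatter is expected in this assay. The estimated step is a 1.2-fold lower number from compound 2 to compound 4 (0.07 log units; within the scatter). For compound 4 the expected value is 3000 nM, within an estimated range of 1200 nM to 8000 nM.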

Compound 4, concentration for 50% growth inhibition: 2100 nM
Estimate against measurement, compound 4: 1.4-fold (0.15 log units) above, within the range that was stated.
By their numbers in this assay, from the lowest: compounds 4, 3 and 2 (each within the scatter of the next); then compound 1.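

At this position, on an aromatic carbon para to a large group, the series now holds three different substituted phenyl groups whose numbers in this assay do not separate. The 3,4-dimethoxyphenyl swap gives a 1.7-fold lower number from compound 2 to compound 4 (0.22 log units; within the scatter), and the exchange against the chlorinated analogue gives a 1.3-fold lower number from compound 3 to compound 4 (0.12 log units; within the scatter). Nothing measured here accounts for this sameness. Still open, on these data alone, is whether an amine or a carboxylic acid on this phenyl ring, or a longer chain in its place, would move the number beyond the scatter.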